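Swapping the Saturated Amine Ring on the Shared Core

The compounds below may be only part of what the source reports. "The series", "measured", "known", "first", "only" and "open" are said of these compounds alone.

Compound 1 `CC1CCC(Nc2nc(C(F)(F)F)ccc2CNC(=O)C(C)c2ccc(NS(C)(=O)=O)c(F)c2)CC1`: 27.2 nM
Compound 2 `CC(C(=O)NCc1ccc(C(F)(F)F)nc1NCc1ccc(Cl)cc1)c1ccc(NS(C)(=O)=O)c(F)c1`: 65.7 nM
Compound 3 `CCCCOC1CCN(c2nc(C(F)(F)F)ccc2CNC(=O)C(C)c2ccc(NS(C)(=O)=O)c(F)c2)CC1`: 3.5 nM

All three compounds were tested in a functional assay on CHO-K1 cells for antagonist activity at transient receptor potential cation channel subfamily V member 1 (Homo sapiens), read by FLIPR (on this read-out higher numbers stand for weaker inhibition and lower numbers for stronger inhibition), and they differ only in the group attached to one aromatic carbon of the shared core. Compound 3 stands lowest of the three, meaning the strongest inhibition: the step of a 7.8-fold lower number from compound 1 to compound 3 (0.89 log units; beyond the scatter) and the step of a 19-fold lower number from compound 2 to compound 3 (1.27 log units; beyond the scatter) both point clearly to it, and the step of a 2.4-fold higher number from compound 1 to compound 2 (0.38 log units; beyond the scatter) separates the other two by less.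

Compound 4 `CC(C(=O)NCc1ccc(C(F)(F)F)nc1N1CCN(C2CCCCC2)CC1)c1ccc(NS(C)(=O)=O)c(F)c1` has not yet been measured. It differs from compound 3 by a group of 12 heavy atoms (10 carbon, 2 nitrogen; one six-membered non-aromatic ring of carbon only, one six-membered non-aromatic ring with 2 hetero atoms) in place of a group of 11 heavy atoms (9 carbon, 1 nitrogen, 1 oxygen; one six-membered non-aromatic ring with 1 hetero atom), on an aromatic carbon. The three measured steps all concern the same position, so all of them bear on this change, though none of them is the same change. The two compounds carrying a saturated ring on that carbon, compound 1 with 27.2 nM and compound 3 with 3.5 nM, both sit below compound 2 with 65.7 nM, and compound 4 again carries a saturated ring there. The expectation is therefore a number between those of compound 1 and compound 3, that is an upward step a 4.3-fold higher number from compound 3 to compound 4 (0.63 log units; beyond the scatter) from compound 3. Compound 4 is estimated at 15 nM, with a likely range from 4 nM to 60 nM.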

Compound 4, inhibition constant: 21.6 nM
Compound 4: the middle estimate sits 1.4-fold (0.16 log units) below what was measured, within the range that was stated.
By their numbers in this assay, from the lowest: compound 3; then compounds 4 and 1 (each within the scatter of the next); then compound 2.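

Compound 4 shows that a saturated ring on this carbon does not by itself bring the low number of compound 3: the 4-cyclohexylpiperazin-1-yl group gives a 6.2-fold higher number from compound 3 to compound 4 (0.79 log units; beyond the scatter) in this assay even though the group that leaves and the group that enters have the same counts of hydrogen-bond donors and acceptors, so those counts do not tell the two apart. Against the (4-methylcyclohexyl)amino group the new group gives a 1.3-fold lower number from compound 1 to compound 4 (0.10 log units; within the scatter) and so the two cannot be told apart in this read-out, although the group of compound 4 is the larger one. Against the (4-chlorobenzyl)amino group it gives a 3.0-fold lower number from compound 2 to compound 4 (0.48 log units; beyond the scatter) and so it remains clearly better, which leaves compound 3 as the only one of the four that stands apart at the low end.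

The compounds shown do not separate the oxygen in the group of compound 3 from the chain that carries it, so an all-carbon chain of similar length, a longer chain, or a chain ending in an amine or a carboxylic acid would be the informative next groups at this position. Nothing measured here gives a reason for these differences.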